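Notes on the step from compound 1 to compound 3

A few compounds are considered here, and "the series" means these few. Any claim that something is new, unique, unknown or untested is made for them only; others in the source may bear on it.

compound 1 `Cc1cc(C)c(CN2CCc3c(Cl)cc([C@H](CO)[C@@H]4CCCO4)c(Cl)c3C2=O)c(=O)[nH]1` gives 57 nM
compound 2 `CCOC(c1cc(Cl)c2c(c1Cl)C(=O)N(Cc1c(C)cc(C)[nH]c1=O)CC2)C1CS(=O)(=O)C1` gives 5560 nM; 34 nM (2 entries)

Going by the values given here, in a functional assay on KARPAS-422 cells (Homo sapiens) for antiproliferative activity, read by resazurin assay, with a stated time of 72 h (on this read-out lower numbers stand for stronger inhibition and higher numbers for weaker inhibition), compound 1 gives 57 nM as its only single number, and one further entry carries no single number. Compound 3 `Cc1cc(C)c(CN2CCc3c(Cl)cc(-c4c(C)noc4C)c(Cl)c3C2=O)c(=O)[nH]1` differs from compound 1 by a group of 7 heavy atoms (5 carbon, 1 nitrogen, 1 oxygen; one five-membered aromatic ring with 2 hetero atoms) in place of a group of 8 heavy atoms (6 carbon, 2 oxygen; one five-membered non-aromatic ring with 1 hetero atom), on an aromatic carbon and carries the 3,5-dimethyl-1,2-oxazol-4-yl group on an aromatic carbon, ortho to a chloro group. Among the compounds with values here, no measured pair shows this change. A weakening beyond the scatter is expected, estimated as a 6.1-fold higher number from compound 1 to compound 3 (0.79 log units; beyond the scatter) in this assay for this step. The range stays wide because the several entries of compound 2 in this assay, 5560 nM; 34 nM (2 entries) lie far apart for compound 2. Compound 3 is expected at 350 nM with an estimated range of 60 nM to 2500 nM in this assay overall.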

Compound 3, half-maximal inhibitory concentration: 23 nM
Beside the measured number, compound 3's estimate is 15-fold (1.18 log units) above it; the whole stated range lies above it.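

In this assay, placing 3,5-dimethyl-1,2-oxazol-4-yl on this aromatic carbon, ortho to a chloro group, gives a 2.5-fold lower number from compound 1 to compound 3 (0.39 log units; beyond the scatter), a modest strengthening. At this position, activity in this read-out therefore does not depend on the leaving group's hydrogen-bond donor, its defined stereocentres or its non-aromatic ring. Nothing shown accounts for the size of this step.

Still open, on these data alone, is whether the two methyl groups on the new ring contribute. Also open, as far as these compounds go, is how a phenyl or pyridine ring would compare at this position.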